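The source may report more compounds than this note shows. Statements on the series, on what has been measured and on what is new or still open speak of the compounds shown alone.

In a functional assay on MCF7 cells (Homo sapiens) for inhibition, read by MTT assay, with a stated time of 5 days (a higher number here means a weaker inhibitor, a lower number a stronger inhibitor), compound 1 `Cc1cc(Nc2nc(NCc3ccccc3Br)nc3[nH]ncc23)n[nH]1` gives 14100 nM and compound 2 `Cc1cc(Nc2nc(NCc3ccc(Cl)cc3)nc3[nH]ncc23)n[nH]1` gives 860 nM as the lower of the two numbers, with a gap beyond the scatter. Compound 2 is therefore the stronger inhibitor of this pair. Compound 3 `Cc1cc(Nc2nc(NCc3ccc(Br)cc3)nc3[nH]ncc23)n[nH]1` differs from compound 2 in one place, by bromo in place of chloro on an aromatic carbon, para to a large group (bromo in place of chloro on an aromatic carbon). For the measured compounds named here, the only measured step bearing on this change is large: a 16-fold lower number from compound 1 to compound 2 (1.21 log units; beyond the scatter) with 4-chlorophenyl in place of 2-bromophenyl. That step changes both the halogen and where it sits on the ring, so it cannot show what the halogen change alone does. Going by the values given here, no measured pair exchanges chloro for bromo at one unchanged position. With the position kept as in compound 2, no step beyond the scatter is expected in this assay and no clear direction can be given. The estimated step (a 1.1-fold lower number from compound 2 to compound 3 (0.03 log units; within the scatter)) is accordingly small. For compound 3 the expected value is 800 nM with an estimated range from 350 nM to 1900 nM in this measurement.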

Compound 3, half-maximal inhibitory concentration: 5340 nM
For compound 3 the middle estimate is 6.7-fold (0.82 log units) below the measured one, and the stated range ends below it.
By their numbers in this assay, from the lowest: compound 2; then compound 3; then compound 1.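

With the halogen's place held constant, bromo in place of chloro gives a 6.2-fold higher number from compound 2 to compound 3 (0.79 log units; beyond the scatter) in this assay and so shows that the identity of the halogen on this aromatic carbon matters by itself, which the earlier mixed change could not show. With bromo held constant, the shift from 2-bromophenyl to 4-bromophenyl gives a 2.6-fold lower number from compound 1 to compound 3 (0.42 log units; beyond the scatter) and shows that the halogen's place also matters, so the larger step from the first pair, a 16-fold lower number from compound 1 to compound 2 (1.21 log units; beyond the scatter) in this assay, can now be read as the sum of two changes, each beyond the scatter. Nothing available gives a reason for either of these steps.

The compounds shown leave open where fluoro, methyl or methoxy on this same aromatic carbon would fall relative to compound 2 and compound 3. For the compounds shown here, they also leave open whether chloro would keep its advantage over bromo in the 2-chlorophenyl form, since the comparison of the two halogens rests on the single position in compound 2 and compound 3.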